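The source may report more compounds than this note shows. Statements on the series, on what has been measured and on what is new or still open speak of the compounds shown alone.

Of the compounds shown here, three with closely related cores have been measured in an ADME assay on HEp-2 cells (Homo sapiens) for cytotoxicity, read by MTT assay, with a stated time of 60 h; a lower number here means that less compound is tolerated, a higher number that more compound is tolerated. Compound 3 `Cc1c(Br)cc2nc3n(c2c1Br)[C@H]1OC[C@@H](O)[C@H]1OC3`, which carries a free hydroxy group, gives 250000 nM, the highest of the three numbers. Compound 2 `Cc1c(Br)cc2nc3n(c2c1Br)[C@H]1OC[C@@H](OS(C)(=O)=O)[C@H]1OC3`, which has methylsulfonyl on that oxygen, gives 23700 nM. Compound 1 `Cc1ccc(S(=O)(=O)O[C@@H]2CO[C@H]3[C@@H]2OCc2nc4cc(Br)c(Br)cc4n23)cc1`, which has a different sulfonyl-containing group there and a slightly different core, gives 87500 nM.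

Compound 4 `Cc1c(Br)cc2nc3n(c2c1Br)[C@H]1OC[C@@H](OCc2ccccc2)[C@H]1OC3` is made from the structure of compound 3 by a single change at the same oxygen: benzyl in place of hydrogen on an oxygen on a saturated carbon. This turns hydroxy to benzyloxy.

Going by the values given here, only one measured step involves this oxygen alone: an 11-fold higher number from compound 2 to compound 3 (1.02 log units; beyond the scatter), a large step towards the free hydroxy. Among the compounds with values here, compound 4 moves the other way, since the hydrogen is replaced, but the incoming group is benzyl rather than methylsulfonyl, and no benzyl compound has been measured yet. Compound 1 also lies lower than compound 3, but its core differs as well, so it offers only loose support. A move to a lower number is therefore expected, probably smaller than the measured step. The estimated change is a 3.6-fold lower number from compound 3 to compound 4 (0.55 log units; beyond the scatter).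

For compound 4, the expected value in this assay is 70000 nM, with an estimated range from 20000 nM to 220000 nM.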

Compound 4, half-maximal cytotoxic concentration: 115000 nM
Estimate against measurement, compound 4: 1.6-fold (0.22 log units) below, within the range that was stated.
By their numbers in this assay, from the lowest: compound 2; then compounds 1 and 4 (each within the scatter of the next); then compound 3.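

Putting a group on this oxygen does not always cost the same: in this assay, there is a 2.2-fold lower number from compound 3 to compound 4 (0.34 log units; beyond the scatter), whereas the step with methylsulfonyl on the same oxygen is larger, at an 11-fold higher number from compound 2 to compound 3 (1.02 log units; beyond the scatter). Losing the hydroxy hydrogen therefore cannot be the whole story, since the two groups that replace it give different results, and the direct comparison of those groups shows a 4.9-fold higher number from compound 2 to compound 4 (0.69 log units; beyond the scatter). So in this small set, what matters at this position is which group is attached as well as whether the hydrogen is replaced, although nothing available here explains why benzyl and methylsulfonyl differ.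

On the shared core, only hydroxy, methylsulfonyl and benzyloxy can be compared at this oxygen, so these results do not establish a general trend with size or type of group. How a simple methyl on the oxygen, a longer chain ending in the same aromatic ring, or an amine in place of the hydroxy would fall in this assay remains an open question.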